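The compounds below may be only part of what the source reports. "The series", "measured", "known", "first", "only" and "open" are said of these compounds alone.

Within the data shown here, in a functional assay on the whole organism with Rattus norvegicus as the target (a lower number here means that less compound is needed, a higher number that more compound is needed for the effect), three compounds with a shared core have numbers so far. Compound 1 (`Cn1c(=N)sc2cc(OC(F)(F)F)ccc21`) stands at 5 mg/kg and compound 2 (`CCCCn1c(=N)sc2cc(OC(F)(F)F)ccc21`) at 10 mg/kg while compound 3 (`N=c1sc2cc(OC(F)(F)F)ccc2n1CCS(N)(=O)=O`) reads 6 mg/kg on the same scale. Compound 3 therefore sits within the scatter of both the others and holds no separate place among them. The two gaps that define its position are a 1.2-fold higher number from compound 1 to compound 3 (0.08 log units; within the scatter) and a 1.7-fold lower number from compound 2 to compound 3 (0.22 log units; within the scatter) as the numbers show.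

Compound 4 (`CSCCn1c(=N)sc2cc(OC(F)(F)F)ccc21`) has not yet been measured. Compared with compound 3 it carries methylsulfanyl in place of sulfamoyl on a saturated chain carbon, two bonds along the chain from an aromatic nitrogen and is otherwise the same.

Among the measured compounds shown here, no measured step brings in methylsulfanyl, so the only guide is the other steps on this chain. The nearest is a 1.7-fold lower number from compound 2 to compound 3 (0.22 log units; within the scatter) which also swaps the sulfamoyl group, and the remaining one is a 2.0-fold higher number from compound 1 to compound 2 (0.30 log units; within the scatter) with the same verdict. All three steps on this chain stay within the scatter, and none of the three compounds goes against that. A step beyond the scatter in this assay is therefore not expected here. The expected step is a 1.2-fold higher number from compound 3 to compound 4 (0.07 log units; within the scatter) and so no real change. Compound 4 is estimated at 7 mg/kg with 3 mg/kg to 15 mg/kg as the expected range.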

Compound 4, dose for half-maximal effect: 1 mg/kg
For compound 4 the middle estimate is 7.0-fold (0.85 log units) above the measured one; the whole stated range lies above it.
By their numbers in this assay, from the lowest: compound 4; then compounds 1, 3 and 2 (each within the scatter of the next).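

Until now, changing the group on this chain had moved the number in this assay only within the scatter, so the position could have seemed tolerant of almost any change. Replacing sulfamoyl with methylsulfanyl on a saturated chain carbon, two bonds along the chain from an aromatic nitrogen, breaks that picture by giving a 6.0-fold lower number from compound 3 to compound 4 (0.78 log units; beyond the scatter) and shows that this place does respond to the group it carries. The two other new steps, a 10-fold lower number from compound 2 to compound 4 (1.00 log units; beyond the scatter) and a 5.0-fold lower number from compound 1 to compound 4 (0.70 log units; beyond the scatter) also lie beyond the scatter, so the 2-(methylsulfanyl)ethyl chain stands apart from all three earlier chains, and no measurement available here explains why.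

The compounds shown leave open whether the sulfur atom itself matters, which a 2-methoxyethyl chain in the same place would help to separate, and whether the distance from the core matters, which a longer chain such as 3-(methylsulfanyl)propyl would address. Going by these compounds, with only these four compounds in this assay it also stays open how an amine or a carboxylic acid at the end of this chain would compare.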